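A few compounds are considered here, and "the series" means these few. Any claim that something is new, unique, unknown or untested is made for them only; others in the source may bear on it.

Among the measured compounds shown here, compound 1 `COC(=O)[C@@]1(C)CCC=C2[C@@H]1CC[C@@H](C)[C@]2(C)Cc1c[nH]c2ccccc12` is one of only two compounds measured in a functional assay on WiDr cells (Homo sapiens) for inhibition, read by sulforhodamine B assay, with a stated time of 48 h (a lower number here means a stronger inhibitor of growth, a higher number a weaker inhibitor of growth), where compound 1 gives 8700 nM. For the measured compounds named here, its single neighbour, compound 2 `COC(=O)[C@@]1(C)CCC=C2[C@@H]1CC[C@@H](C)[C@]2(C)Cc1c[nH]c2ccc(OC)cc12`, gives 5700 nM in this assay, and the step of a 1.5-fold lower number from compound 1 to compound 2 (0.18 log units; within the scatter) leaves the two level. Compound 3 `COC(=O)[C@@]1(C)CCC=C2[C@@H]1CC[C@@H](C)[C@]2(C)Cc1c[nH]c2c(Cl)cccc12` differs from compound 1 by chloro in place of hydrogen on an aromatic carbon. Going by the values given here, the one measured step, a 1.5-fold lower number from compound 1 to compound 2 (0.18 log units; within the scatter), concerns a different group at a different place and gives no guide to chloro, so no step beyond the scatter is expected in this assay. Compound 3 is therefore estimated at 8000 nM, between 3500 nM and 18000 nM, an expected step of a 1.1-fold lower number from compound 1 to compound 3 (0.04 log units; within the scatter).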

Compound 3, concentration for 50% growth inhibition: 31000 nM
The estimate for compound 3 lay 3.9-fold (0.59 log units) below the measured number, and the stated range ends below it.
By their numbers in this assay, from the lowest: compounds 2 and 1 (each within the scatter of the next); then compound 3.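

In this assay, chloro in place of hydrogen on this aromatic carbon, ortho to a fused ring, gives a 3.6-fold higher number from compound 1 to compound 3 (0.55 log units; beyond the scatter) and so weakens growth inhibition. This is the first step shown that lies beyond the scatter, which shows that this carbon of the six-membered aromatic ring is sensitive to substitution by chloro. Nothing available explains this loss.

The compounds shown leave open whether the loss is specific to chloro or would also follow with fluoro or methyl on this carbon. They also leave open how chloro would fare on the other carbons of this ring.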